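The compounds below may be only part of what the source reports. "The series", "measured", "known", "first", "only" and "open" are said of these compounds alone.

Measured, in an assay on isolated protein for inhibition of Indoleamine 2,3-dioxygenase 1 (Homo sapiens); on this read-out lower numbers stand for stronger inhibition and higher numbers for weaker inhibition:
compound 1 `OCc1cn(CCNc2nonc2/C(=N/O)Nc2ccc(F)c(Br)c2)nn1`, 77 nM
compound 2 `CC(C)(C)c1cn(CCNc2nonc2/C(=N/O)Nc2ccc(F)c(Br)c2)nn1`, 132 nM
compound 3 `OCCCCc1cn(CCNc2nonc2/C(=N/O)Nc2ccc(F)c(Br)c2)nn1`, 80 nM

Compound 3 is not separated from either of the other two: a 1.0-fold higher number from compound 1 to compound 3 (0.02 log units; within the scatter) and a 1.7-fold lower number from compound 2 to compound 3 (0.22 log units; within the scatter), so all three numbers sit together. Compound 4 `CC(O)c1cn(CCNc2nonc2/C(=N/O)Nc2ccc(F)c(Br)c2)nn1` is not yet measured; it carries 1-hydroxyethyl in place of 4-hydroxybutyl on an aromatic carbon. For the measured compounds named here, the steps that bear on this are the changes of the same substituent on the five-membered aromatic ring with 3 nitrogen: a 1.0-fold higher number from compound 1 to compound 3 (0.02 log units; within the scatter), a 1.7-fold higher number from compound 1 to compound 2 (0.23 log units; within the scatter) and a 1.7-fold lower number from compound 2 to compound 3 (0.22 log units; within the scatter), every one within the scatter, whether the group is short or long and with or without the hydroxy. No step beyond the scatter is therefore expected in this assay; the expected step is a 1.1-fold higher number from compound 3 to compound 4 (0.03 log units; within the scatter). Compound 4 is estimated at 85 nM, with a range of 45 nM to 165 nM.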

Compound 4, half-maximal inhibitory concentration: 53 nM
The estimate for compound 4 lay 1.6-fold (0.21 log units) above the measured number, within the range that was stated.
By their numbers in this assay, from the lowest: compounds 4, 1, 3 and 2 (each within the scatter of the next, the first and the last beyond it).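

In this assay, for the compounds shown here, 1-hydroxyethyl gives the first step at this position that lies beyond the scatter, a 2.5-fold lower number from compound 2 to compound 4 (0.40 log units; beyond the scatter), though compound 2 remains within the scatter of compound 1 and compound 3. Neither the added methyl, a 1.5-fold lower number from compound 1 to compound 4 (0.16 log units; within the scatter), nor the change from 4-hydroxybutyl, a 1.5-fold lower number from compound 3 to compound 4 (0.18 log units; within the scatter), separates the hydroxy-bearing compounds from one another. Nothing available bears on the cause of these results.

Open, from the compounds shown here alone, is whether an amine or a carboxylic acid in place of the hydroxy on the 1-hydroxyethyl chain would keep the number of compound 4.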